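The source may report more compounds than this note shows. Statements on the series, on what has been measured and on what is new or still open speak of the compounds shown alone.

The compounds measured so far:

Compound 1, `CCOC(=O)C(=O)CC(=O)/C=C/c1cn(CCC(C)C)c2ccccc12`, in an assay on isolated protein for inhibition of DNA nucleotidylexotransferase (Homo sapiens), read by scintillation counting, with a stated time of 10 min (on this read-out higher numbers stand for weaker inhibition and lower numbers for stronger inhibition), gives > 40 uM, which is a limit of the assay and not a number.
Compound 2, `C/C=C/Cn1cc(/C=C/C(=O)CC(=O)C(=O)OCC)c2ccccc21`, in this assay gives > 40 uM, again a limit.
Compound 3, `CCOC(=O)C(=O)CC(=O)/C=C/c1cn(-c2ccc(Cl)cc2)c2ccccc12`, in this assay gives > 40 uM, also a limit.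

Compound 3 therefore stands at a limit, as do the two others, and no order among the three can be read: the limit of > 40 uM in this assay, at which 3 of the 3 values shown sit. The change to compound 4, `CCOC(=O)C(=O)CC(=O)/C=C/c1cn(CC(=O)N2CCOCC2)c2ccccc12`, is ((morpholin-4-yl)carbonyl)methyl in place of 4-chlorophenyl on an aromatic nitrogen. Among the measured compounds shown here, two measured steps touch the same aromatic nitrogen, a step that the two limits leave unreadable from compound 1 to compound 3 and a step that the two limits leave unreadable from compound 2 to compound 3, but both run between limits, so their size is not readable. With no readable step in hand, the expectation for compound 4 rests on the position of compound 3 alone: compound 4 is expected to sit near the same limit, the step that the limit leaves unreadable from compound 3 to compound 4 being an estimate without measured support. The estimated value for compound 4 in this assay is 60 uM, expected to fall between 15 uM and 300 uM.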

Compound 4, concentration for 50% inhibition: > 40 uM
Compound 4 ended at the assay's limit; the forecaster's own chance of this, stated with the estimate: 80%; the middle value does not contradict the limit.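

Among the compounds shown here, no step to compound 4 from compound 1, compound 2 or compound 3 can be read, since all of them sit at one limit: the limit of > 40 uM in this assay, at which 4 of the 4 values shown sit. The compounds shown leave open how strongly each one inhibits, and whether the group on the aromatic nitrogen changes this at all.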